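A few compounds are considered here, and "the series" means these few. Any claim that something is new, unique, unknown or untested is made for them only; others in the source may bear on it.

Working notes on the series. Among the compounds with values here, in a physicochemical assay for acid dissociation, compound 1 `Cn1cc(-c2ccc3nc(N4CCN(C5CCC5)CC4)ncc3c2)ccc1=O` gives 6.1, the only number available so far. Compound 2 `Cc1cc(-c2ccc(=O)n(C)c2F)cc2cn(C3CCNCC3)nc12` stands as "not determined" (no result reported), so it offers no number to start from. Compound 3 `Cc1cc(-c2ccc(=O)n(C)c2Cl)cc2cn(C3CCNCC3)nc12` awaits measurement. The structural change is chloro in place of fluoro on an aromatic carbon, next to the ring nitrogen. Within the data shown here, no measured step in this assay bears on this swap, and on the swap alone no step beyond the usual scatter is expected, in either direction. The absolute level remains poorly anchored. Compound 3 differs from compound 1 in much more than one place, so compound 1 at 6.1 serves only as a loose reference, and a wide range is needed. For compound 3 the expected value is 9.2, with an estimated range of 8.3 to 10.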

Compound 3, acid dissociation constant: 9.2
For compound 3 middle estimate and measured number coincide at the digits printed; the measured number falls inside the stated range.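

In this assay compound 3 gives 9.2 and compound 2 stands as "not determined" (no result reported) so no step can be read for chloro in place of fluoro. Nothing at hand accounts for the value of compound 3. As far as these compounds go, what this swap alone does to the read-out remains open.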